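This account rests on a few compounds, and the source may have more. Where it says the series, first, only, none or still open, it means among the compounds named here.

Compound 1 `CCOC(=O)C1=C(C)NC(=S)NC1c1cccc(OCCCCCOc2cccc(C3NC(=S)NC(C)=C3C(=O)OCC)c2)c1`: 74 ug/mL
Compound 2 `CCOC(=O)C1=C(C)NC(=S)NC1c1cccc(OC/C=C\COc2cccc(C3NC(=S)NC(C)=C3C(=O)OCC)c2)c1`: 190 ug/mL

Both numbers come from a functional assay on A-431 cells (Homo sapiens) for cytotoxicity, read by MTT assay, with a stated time of 48 h; on this read-out higher numbers stand for weaker inhibition and lower numbers for stronger inhibition. Of the two, compound 2 stands higher at 190 ug/mL, which marks it as the weaker inhibitor of the pair. Compound 1 lies lower at 74 ug/mL, and that gap is beyond the scatter.

Compound 3 `CCOC(=O)C1=C(C)NC(=S)NC1c1cccc(OC/C=C/COc2cccc(C3NC(=S)NC(C)=C3C(=O)OCC)c2)c1` has yet to be measured in this assay. It differs from compound 2 in a single feature: the two compounds have the same atoms and bonds; at least one stereo element is drawn with a configuration in one of them and without one in the other: 1 of 3 stereo elements differ; a double bond is drawn Z in compound 2 and E in compound 3. The two compounds have the same atoms and bonds, and a double bond is drawn Z in compound 2 and E in compound 3. Going by the values given here, no measured pair shows a change of this kind, so the size of the step can only be judged loosely. The starting point is compound 2 at 190 ug/mL, and compound 1 at 74 ug/mL shows that this series can reach lower numbers. A slight move toward a lower number is expected, though none beyond the scatter, and the estimated step is a 1.3-fold lower number from compound 2 to compound 3 (0.10 log units; within the scatter). For compound 3 the expected value is 150 ug/mL, with an estimated range from 70 ug/mL to 320 ug/mL.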

Compound 3, half-maximal inhibitory concentration: 185 ug/mL
Beside the measured number, compound 3's estimate is 1.2-fold (0.09 log units) below it; low and high end bracket the measured number.
By their numbers in this assay, from the lowest: compound 1; then compounds 3 and 2 (each within the scatter of the next).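

In this assay, going by these compounds alone, the only change between the two compounds is the geometry of the double bond in the linking chain, and the result is a 1.0-fold lower number from compound 2 to compound 3 (0.01 log units; within the scatter). Within the data shown here, this is the first comparison that isolates a single feature, since compound 1 differs from the other two in the chain as a whole, and it shows that at this double bond the choice between the Z and the E form does not separate the two compounds on this read-out. One reservation applies to this reading, which rests on the drawn structures and is limited by the following: the fact that one of compounds 2 and 3 is drawn with a defined configuration and the other without, at the place where they differ.

The compounds shown leave open what other changes to the linking chain would do, such as a triple bond in place of the double bond, or a longer chain that keeps the double bond. They also leave open how the series would respond to changes outside the chain, for example a carbonyl in place of the thiocarbonyl or a carboxylic acid in place of the ethyl ester.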